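Replacing a pentylseleno chain with amino on compound 1

The source may report more compounds than this note shows. Statements on the series, on what has been measured and on what is new or still open speak of the compounds shown alone.

Compound 1 `CCCCC[Se]c1nc([Se]CCCCC)c2ccccc2n1` was tested in a functional assay on HT-29 cells (Homo sapiens) for cytotoxicity, read by MTT assay, with a stated time of 72 h; on this read-out higher numbers stand for weaker inhibition of growth and lower numbers for stronger inhibition of growth. In this assay compound 1 gives > 100000 nM, which is a limit of the assay rather than a number. Compound 2 `CSc1nc(NCc2ccc([Se]C)cc2)c2ccccc2n1` likewise reaches only a limit, giving > 100000 nM in this assay. Compound 3 `Nc1nc([SeH])nc2ncccc12`, which carries an amino group on a different core, gives 36300 nM in this assay. Among the measured compounds shown here, compound 1 thus stands at the limit of > 100000 nM in this assay, at which 2 of the 3 values shown sit, and no step between two measured compounds is available to calibrate the change. Compound 4 `CCCCC[Se]c1nc(N)c2ccccc2n1` differs from compound 1 in one place: one nitrogen atom in place of a group of 6 heavy atoms (5 carbon, 1 selenium; no ring), on an aromatic carbon. For the measured compounds named here, with no measured step to lean on, the direction is uncertain, but compound 3 with its amino group gives 36300 nM, a measurable number, so a move toward measurable growth inhibition is expected rather than none. The step from compound 1 to compound 4 is expected to be an at least 2.0-fold lower number from compound 1 to compound 4 (0.30 log units; that floor lies within the scatter). Compound 4 is estimated at 50000 nM, with a range from 10000 nM to 200000 nM in this assay.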

Compound 4, concentration for 50% growth inhibition: 40300 nM
Estimate against measurement, compound 4: 1.2-fold (0.09 log units) above; the range from low to high includes it.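

Among the compounds shown here, on the aromatic carbon next to the ring nitrogen, putting amino in place of the pentylseleno chain gives, in this assay, an at least 2.4-fold lower number from compound 1 to compound 4 (0.39 log units; beyond the scatter) and brings the core of compound 1 to a measurable number for the first time. This is the first step shown on this core, and it shows that this one position can move the read-out even while the second pentylseleno chain stays in place. The true size of the step remains unknown, and the printed size is only a floor, because compound 1 sits at a limit: the limit of > 100000 nM in this assay, at which 2 of the 4 values shown sit.

The compounds shown cannot separate the loss of the chain from the arrival of amino. On these data alone, it remains open whether a shorter ethylseleno chain or a methylamino group at this position would give a similar change.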